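Working notes: from compound 3 to compound 4

A few compounds are considered here, and "the series" means these few. Any claim that something is new, unique, unknown or untested is made for them only; others in the source may bear on it.

Compound 1 `c1ccc(CSc2nnc(-c3ccc4c(c3)OCCO4)n2-c2ccccc2)cc1`: 73400 nM
Compound 2 `O=[N+]([O-])c1ccc(CSc2nnc(-c3ccc4c(c3)OCCO4)n2-c2ccccc2)cc1`: 48600 nM
Compound 3 `Clc1cccc(CSc2nnc(-c3ccc4c(c3)OCCO4)n2-c2ccccc2)c1`: 51200 nM

In a functional assay on BGC-823 cells (Homo sapiens) for antiproliferative activity, read by MTT assay, with a stated time of 24 h (a higher number here means a weaker inhibitor, a lower number a stronger inhibitor), compound 3 gives 51200 nM, within the scatter of both compound 1 and compound 2. Compound 4 `Fc1ccc(CSc2nnc(-c3ccc4c(c3)OCCO4)n2-c2ccccc2)cc1` differs from compound 3 by 4-fluorophenyl in place of 3-chlorophenyl on a saturated chain carbon bound to a sulfur, with 4-fluorophenyl in place of 3-chlorophenyl on a saturated chain carbon bound to a sulfur. For the measured compounds named here, three measured steps bear on this change: a 1.5-fold lower number from compound 1 to compound 2 (0.18 log units; within the scatter), a 1.4-fold lower number from compound 1 to compound 3 (0.16 log units; within the scatter) and a 1.1-fold higher number from compound 2 to compound 3 (0.02 log units; within the scatter). The last of these exchanges the group at that same place, and all three stay within the scatter. Going by the values given here, no measured step brings in fluoro, so this remains an extrapolation. No step beyond the scatter is expected in this assay, and the estimated step is a 1.0-fold higher number from compound 3 to compound 4 (0.01 log units; within the scatter). For compound 4 the estimated value is 52000 nM, with an expected range of 26000 nM to 90000 nM.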

Compound 4, half-maximal inhibitory concentration: > 100000 nM
Compound 4: no number, only a limit (the forecaster's own chance of this, stated with the estimate: 5%); middle value at least 1.9-fold (0.28 log units) from the limit.
By their numbers in this assay, from the lowest: compounds 2, 3 and 1 (each within the scatter of the next). At a limit, above all of these: compound 4.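

In this assay compound 4 gives no number, only a limit of the assay: the limit of > 100000 nM in this assay, at which 1 of the 4 values shown sits.
Compounds 1, 2 and 3 stay within the scatter of one another, but this position now shows a step beyond the scatter, for fluoro in place of nitro on an aromatic carbon (an at least 2.0-fold higher number from compound 2 to compound 4 (0.31 log units; beyond the scatter)). The floors of the other two steps lie within the scatter (an at least 1.9-fold higher number from compound 3 to compound 4 (0.29 log units; that floor lies within the scatter); an at least 1.3-fold higher number from compound 1 to compound 4 (0.13 log units; that floor lies within the scatter)), so neither step shows a real change yet.

Going by these compounds, the full size of all three steps stays open. Also open, on these data alone, is how an aminophenyl or a carboxyphenyl group would read on a saturated chain carbon bound to a sulfur.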